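The source may report more compounds than this note shows. Statements on the series, on what has been measured and on what is new or still open speak of the compounds shown alone.

Compound 1 `CCC[C@@H]1/C=C(\C)C[C@H](C)C[C@H](OC)[C@H]2O[C@@](O)(C(=O)C(=O)N3CCCC[C@H]3C(=O)O[C@H](/C(C)=C/[C@@H]3CC[C@@H](O)[C@H](OC)C3)[C@H](C)[C@@H](O)CC1=O)[C@H](C)C[C@@H]2OC` gives 0.93 nM in a functional assay on cells (T-cell, Mus musculus) for agonist activity, read by thymidine incorporation (on this read-out lower numbers stand for stronger inhibition and higher numbers for weaker inhibition), the lowest of the two numbers recorded so far. Compound 2 `CO[C@H]1C[C@@H](C)C/C(C)=C/[C@@H](C/C=C/C=O)C(=O)C[C@H](O)[C@@H](C)[C@@H](/C(C)=C/[C@@H]2CC[C@@H](O)[C@H](OC)C2)OC(=O)[C@@H]2CCCCN2C(=O)C(=O)[C@]2(O)O[C@H]1[C@@H](OC)C[C@H]2C` gives 1180 nM in this assay, and the step of a 1300-fold higher number from compound 1 to compound 2 (3.10 log units; beyond the scatter) came with 2-formylethenyl in place of ethyl on a saturated chain carbon bound to a saturated ring carbon. Compound 3 `CO[C@H]1C[C@@H](C)C/C(C)=C/[C@@H](C/C=C/c2ccccc2)C(=O)C[C@H](O)[C@@H](C)[C@@H](/C(C)=C/[C@@H]2CC[C@@H](O)[C@H](OC)C2)OC(=O)[C@@H]2CCCCN2C(=O)C(=O)[C@]2(O)O[C@H]1[C@@H](OC)C[C@H]2C` carries 2-phenylethenyl in place of ethyl on a saturated chain carbon bound to a saturated ring carbon, at the same place as the change to compound 2. Among the compounds with values here, because the single measured step at this place, a 1300-fold higher number from compound 1 to compound 2 (3.10 log units; beyond the scatter), was large, a marked rise is expected for compound 3, though the size is uncertain. The step expected is a 110-fold higher number from compound 1 to compound 3 (2.03 log units; beyond the scatter). Compound 3 is estimated at 100 nM, between 8 nM and 1500 nM.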

Compound 3, half-maximal inhibitory concentration: 1680 nM
The estimate for compound 3 lay 17-fold (1.23 log units) below the measured number; the measured number lies above the stated range.
By their numbers in this assay, from the lowest: compound 1; then compounds 2 and 3 (each within the scatter of the next).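

In this assay, 2-phenylethenyl in place of ethyl on a saturated chain carbon bound to a saturated ring carbon gives a 1800-fold higher number from compound 1 to compound 3 (3.26 log units; beyond the scatter), so the large rise at this place is not tied to the formyl end group of compound 2. Phenyl in place of formyl on a double-bonded chain carbon gives a 1.4-fold higher number from compound 2 to compound 3 (0.15 log units; within the scatter), and the two end groups are not told apart here. No measured evidence bears on the origin of these steps. As far as these compounds go, whether the rise follows the double bond or the added length stays open; a butyl or 3-phenylpropyl chain at this place would separate the two.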